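Aryl ether substituent swap on the shared core: permeability

The compounds below may be only part of what the source reports. "The series", "measured", "known", "first", "only" and "open" are said of these compounds alone.

Compound 1 `COc1cccc(CNCCCNc2ccnc3cc(-c4ccc(C(F)(F)F)cc4)ccc23)c1O` carries a 4-(trifluoromethyl)phenyl on the shared core, and in an ADME assay for permeability, using PAMPA, with a stated time of 30 min, at pH 7.4 (a higher number here means that the compound crosses the layer faster, a lower number that the compound crosses the layer more slowly), compound 1 gives 237 10^-6 cm/s. Compound 2 `COc1cccc(CNCCCNc2ccnc3cc(Cc4ccc(F)cc4)ccc23)c1O` gives 23 10^-6 cm/s, and compound 3 `COc1cccc(CNCCCNc2ccnc3cc(Oc4cccc(N(C)C)c4)ccc23)c1O` gives 317 10^-6 cm/s. Compound 3 shows the highest number of the three, but the step of a 1.3-fold higher number from compound 1 to compound 3 (0.13 log units; within the scatter) lies within the scatter, so compound 3 is not separated from compound 1; the large movements in the set are a 10-fold lower number from compound 1 to compound 2 (1.01 log units; beyond the scatter) and a 14-fold higher number from compound 2 to compound 3 (1.14 log units; beyond the scatter).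

Compound 4 `COc1cccc(CNCCCNc2ccnc3cc(Oc4ccc(C(C)(C)C)cc4)ccc23)c1O` keeps the aryl ether of compound 3 and changes only the ring on the oxygen: 4-(tert-butyl)phenyl in place of 3-(dimethylamino)phenyl on an oxygen on an aromatic ring. Among the compounds with values here, no measured step touches a substituent on that ring. The steps of a 10-fold lower number from compound 1 to compound 2 (1.01 log units; beyond the scatter) and a 14-fold higher number from compound 2 to compound 3 (1.14 log units; beyond the scatter) exchange the whole group on the aromatic carbon, and a 1.3-fold higher number from compound 1 to compound 3 (0.13 log units; within the scatter) shows that the move to the aryl ether itself stayed within scatter. Within the data shown here, with no direct precedent for this kind of change, a step of no more than the usual scatter is expected, a 1.1-fold lower number from compound 3 to compound 4 (0.02 log units; within the scatter), in either direction. Compound 4 is therefore estimated at 300 10^-6 cm/s, with an expected range from 150 10^-6 cm/s to 600 10^-6 cm/s.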

Compound 4, apparent permeability: 317 10^-6 cm/s
Compound 4: middle estimate off by 1.1-fold (0.02 log units), on the low side; the measured number falls inside the stated range.
By their numbers in this assay, from the lowest: compound 2; then compounds 1, 3 and 4 (each within the scatter of the next).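

Within the data shown here, the ring on the oxygen changes here for the first time, and in this assay the step of no change at the digits printed from compound 3 to compound 4 (within the scatter) shows that 4-(tert-butyl)phenyl and 3-(dimethylamino)phenyl are not told apart at this place, even though the nitrogen of the leaving group is gone. The second aryl ether also repeats the pattern of the first: a 14-fold higher number from compound 2 to compound 4 (1.14 log units; beyond the scatter) matches a 14-fold higher number from compound 2 to compound 3 (1.14 log units; beyond the scatter) in size, while a 1.3-fold higher number from compound 1 to compound 4 (0.13 log units; within the scatter) stays within the scatter, so compound 2 stands apart and compounds 1, 3 and 4 are not separated from one another. No measurement at hand gives a reason for either result.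

From the compounds shown here alone, compound 2 differs from the other three in both the atom linking the ring to the core and the substituent on that ring, so the source of its lower number stays open. A 4-(trifluoromethyl)benzyl group on the aromatic carbon would separate those two changes, and a carboxylic acid or primary amine on the ring on the oxygen would test whether this position still shows no movement with such groups.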